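Chlorophenyl placement in a hydroxyphenyl pyridine series

This account rests on a few compounds, and the source may have more. Where it says the series, first, only, none or still open, it means among the compounds named here.

Measured compounds:
compound 2 `Oc1ccc(-c2cc(-c3ccccc3)nc(-c3ccccc3Cl)c2)cc1`: 5460 nM in a functional assay on T47D cells (Homo sapiens) for cytotoxicity, read by CCK-8 assay and cell counting, with a stated time of 2 days; on this read-out higher numbers stand for weaker inhibition and lower numbers for stronger inhibition
compound 3 `Oc1ccc(-c2cc(-c3ccco3)nc(-c3ccccc3Cl)c2)cc1`: 5480 nM in this assay

Compound 1 `Oc1ccc(-c2cc(-c3ccccn3)nc(-c3ccccc3Cl)c2)cc1` carries a pyridin-2-yl group on the shared core, but in this assay compound 1 gives "not determined" (no result reported); it stands nowhere on the numbers, and its position is only bracketed by compound 2 and compound 3. Among the measured compounds shown here, the one step available, a 1.0-fold higher number from compound 2 to compound 3 (0.00 log units; within the scatter), shows that swapping the aryl group at that site left the number unchanged within the scatter.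

Compound 4 `Oc1ccc(-c2cc(-c3cccc(Cl)c3)nc(-c3ccccn3)c2)cc1` differs from compound 1 by 3-chlorophenyl in place of 2-chlorophenyl on an aromatic carbon. For the measured compounds named here, no measured pair bears directly on moving the chlorine from one position of the chlorophenyl to another, so no step size can be taken from the data for this assay; the only information is that the aryl variation in compound 2 and compound 3 was flat. The expectation is therefore a number in the same region as compound 2 and compound 3, with wide uncertainty. Compound 4 is estimated at 5500 nM, expected between 1500 nM and 20000 nM.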

Compound 4, half-maximal inhibitory concentration: 27900 nM
For compound 4 the middle estimate is 5.1-fold (0.71 log units) below the measured one; measured number outside the range, above it.
By their numbers in this assay, from the lowest: compounds 2 and 3 (each within the scatter of the next); then compound 4.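

No step can be read between compound 1 and compound 4: compound 1 gives "not determined" (no result reported) in this assay and so offers no number to compare. The compounds shown leave open what 3-chlorophenyl in place of 2-chlorophenyl does to the number on one shared core. Nothing available accounts for the value of compound 4.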